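Working notes on tolerated concentration in a small series

The source may report more compounds than this note shows. Statements on the series, on what has been measured and on what is new or still open speak of the compounds shown alone.

Measured so far:
compound 1 `CC[C@H](CCn1cncn1)c1ccc(C)cc1`: 85.2 ug/mL
compound 2 `CCC[C@H](CCn1cncn1)c1ccc(F)cc1`: 38.4 ug/mL

In an ADME assay on RD cells (Homo sapiens) for cytotoxicity, read by MTT assay, with a stated time of 3 days (a lower number here means that less compound is tolerated, a higher number that more compound is tolerated), compound 1 gives 85.2 ug/mL, and compound 2 gives 38.4 ug/mL. Compound 2 stands lowest of the two numbers; its nearest neighbour is compound 1, whose higher reading lies beyond the scatter. Compound 3 `CCC[C@H](CCn1cncn1)c1ccc(C)cc1` differs from compound 2 by methyl in place of fluoro on an aromatic carbon. Within the data shown here, compound 1 also carries the methyl, but its chain differs as well, so no single step connects that pair to compound 3. A modest upward step is expected for compound 3, a 1.4-fold higher number from compound 2 to compound 3 (0.16 log units; within the scatter), possibly within the scatter. Compound 3 is estimated at 55 ug/mL, range 30 ug/mL to 100 ug/mL.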

Compound 3, half-maximal cytotoxic concentration: 47.2 ug/mL
Estimate against measurement, compound 3: 1.2-fold (0.07 log units) above; low and high end bracket the measured number.
By their numbers in this assay, from the lowest: compounds 2, 3 and 1 (each within the scatter of the next, the first and the last beyond it).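

In this assay, methyl in place of fluoro on an aromatic carbon, para to a large group, gives a 1.2-fold higher number from compound 2 to compound 3 (0.09 log units; within the scatter), so the two groups read alike at this position. Methyl in place of hydrogen on a saturated chain carbon, three bonds along the chain from an aromatic carbon, gives a 1.8-fold lower number from compound 1 to compound 3 (0.26 log units; within the scatter), so neither single change alone separates its pair beyond the scatter. No measured evidence bears on the reason for either step.

Still open, on these data alone, is how an amine or a carboxylic acid on that aromatic carbon would read. As far as these compounds go, a longer chain is equally open.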